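Changing the Group on the Carbonyl Carbon

The source may report more compounds than this note shows. Statements on the series, on what has been measured and on what is new or still open speak of the compounds shown alone.

In a functional assay on MCF7 cells (Homo sapiens), read by MTT assay, with a stated time of 48 h (a higher number here means a weaker inhibitor, a lower number a stronger inhibitor), compound 1 (`CCOC(=O)CN(C)C(=O)c1ccc(C(CC)(CC)c2ccc(OCC(O)C(C)(C)C)c(C)c2)n1CC`) gives 9200 nM and compound 2 (`CC[C@@H](C)[C@H](NC(=O)c1ccc(C(CC)(CC)c2ccc(OCC(O)C(C)(C)C)c(C)c2)n1CC)C(=O)O`) gives 2000 nM as the lower of the two numbers. Compound 3 (`CCn1c(C(=O)N(C)CC(=O)O)ccc1C(CC)(CC)c1ccc(OCC(O)C(C)(C)C)c(C)c1`) differs from compound 2 by (carboxymethyl)(methyl)amino in place of (1-carboxy-2-methylbutyl)amino on a carbonyl carbon in the same place, with (carboxymethyl)(methyl)amino in place of (1-carboxy-2-methylbutyl)amino on a carbonyl carbon. Among the compounds with values here, the one measured step at this place is a 4.6-fold lower number from compound 1 to compound 2 (0.66 log units; beyond the scatter) and it was modest. It partly turns back here, so a smaller rise is expected, and the estimated step is a 2.3-fold higher number from compound 2 to compound 3 (0.35 log units; beyond the scatter) in this read-out. For compound 3 the estimate is 4500 nM with 1500 nM to 13000 nM as the expected range.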

Compound 3, half-maximal inhibitory concentration: 25400 nM
Estimate against measurement, compound 3: 5.6-fold (0.75 log units) below, outside the stated range (above it).
By their numbers in this assay, from the lowest: compound 2; then compound 1; then compound 3.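

Compound 2's gain does not come from the free carboxylic acid alone: in this assay, a 13-fold higher number from compound 2 to compound 3 (1.10 log units; beyond the scatter), a large loss once the (1-carboxy-2-methylbutyl)amino group gives way to (carboxymethyl)(methyl)amino. The ethyl ester is also not the weaker form with this smaller group, since removing its ethyl gives a 2.8-fold higher number from compound 1 to compound 3 (0.44 log units; beyond the scatter). The lower number therefore goes with the (1-carboxy-2-methylbutyl)amino group, not with the acid as such. The compounds shown leave open whether its branched chain or its amide hydrogen matters more, which a (carboxymethyl)amino group would help separate. Nothing shown gives a cause for either step.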